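A few compounds are considered here, and "the series" means these few. Any claim that something is new, unique, unknown or untested is made for them only; others in the source may bear on it.

The series rests on a shared core that carries a trifluoromethyl group and an amine-linked side chain, and its members were examined in an assay for inhibition of Tryptophan 2,3-dioxygenase (Homo sapiens), with stated times of 10 min and 60 min, tested at 10 uM; on this read-out lower numbers stand for a weaker effect and higher numbers for a stronger effect at the one concentration tested. Compound 1, with the structure `FC(F)(F)c1cc(NC[C@H]2CCCN2)c2cn[nH]c2c1`, gives 55% in this assay. Compound 2, `O=[N+]([O-])c1ccc2[nH]c(CNc3cc(C(F)(F)F)cc4[nH]ncc34)cc2c1`, gives 54%, a number that sits within the usual scatter of the number for compound 1, so the two cannot be told apart. Compound 3, `O=[N+]([O-])c1cc(Br)c(F)cc1CNc1cc(C(F)(F)F)cc2[nH]ncc12`, gives 85%, and its gap to compound 1 lies beyond the scatter. On these three numbers compound 1 stands second highest, beneath compound 3 and level with compound 2.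

Compound 4, `FC(F)(F)c1cc(NC[C@H]2CCCCN2)c2cn[nH]c2c1`, has not yet been measured in this assay. It differs from compound 1 in one place: piperidin-2-yl in place of pyrrolidin-2-yl on a saturated chain carbon bound to a nitrogen on an aromatic ring. The change replaces one saturated ring by a ring one member larger on the same saturated chain carbon bound to a nitrogen on the aromatic ring, and the counts of hydrogen-bond donors and acceptors, charge and stereocentres stay the same. Going by the values given here, no measured pair in the set shows this change, so there is no step to lean on. The step is expected to be small, a number 5 percentage points lower from compound 1 to compound 4 (within the scatter), with no direction beyond the scatter. Compound 4 is therefore estimated to give 50% in this assay, most likely between 30% and 70%.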

Compound 4, a percentage reported as inhibition, at one concentration (the size of the read-out at that concentration, not a potency): 69%
The estimate for compound 4 lay 19 percentage points below the measured number; measured number inside the range.
By their numbers in this assay, from the lowest: compounds 2 and 1 (each within the scatter of the next); then compound 4; then compound 3.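

The exchange of pyrrolidin-2-yl for piperidin-2-yl on a saturated chain carbon bound to a nitrogen on an aromatic ring gives a number 14 percentage points higher from compound 1 to compound 4 (beyond the scatter) in this assay. Going by these compounds alone, this is the first single-place comparison in the set, and it shows that the read-out at this position responds to a ring that is one member larger, while the counts of hydrogen-bond donors and acceptors, the net charge and the number of defined stereocentres stay the same. No measurement at hand explains why the larger ring gives the higher number.

The compounds shown leave open whether this response continues with a still larger ring such as azepan-2-yl, reverses with a smaller one such as azetidin-2-yl, or depends on the ring at all, as an open-chain amine at the same place would test. They also leave open whether a ring oxygen, as in morpholin-3-yl, or the opposite arrangement at the defined stereocentre would keep the gain, and a single step cannot settle whether it would hold on other forms of the shared core.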